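The source may hold more compounds than are shown below. What is called first, only, known or untested is meant among the compounds shown, and "the series" means these compounds.

Measured so far in an in vitro ADME assay on microsomes from liver (Homo sapiens) for metabolic stability (on this read-out lower numbers stand for a shorter-lived compound and higher numbers for a longer-lived compound), both as limits:
- compound 1 `Cc1nc2ccc(-c3ccccc3Cl)c(CN)c2n1C` gives > 3.33 h (a limit)
- compound 2 `COCc1nc2ccc(-c3ccccc3Cl)c(CN)c2n1C` gives > 3.33 h (a limit)

Compound 2 has no number, only a limit (the limit of > 3.33 h in this assay, at which 2 of the 2 values shown sit). Compound 3 `Cn1c(-c2cccnc2)nc2ccc(-c3ccccc3Cl)c(CN)c21` differs from it by pyridin-3-yl in place of methoxymethyl on an aromatic carbon. Among the measured compounds shown here, the one measured step, a step that the two limits leave unreadable from compound 1 to compound 2, has no readable size and sets no size to carry over. No shift beyond the scatter is therefore expected, and no direction is favoured. The expected step is a step that the limit leaves unreadable from compound 2 to compound 3 in this assay on this estimate. For compound 3 the estimated value is 3.5 h (expected range 1.5 h to 8 h).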

Compound 3, half-life: 1.6 h
Compound 3: the middle estimate sits 2.2-fold (0.34 log units) above what was measured; measured number inside the range.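

In this assay, the aromatic carbon between two ring nitrogen atoms proves sensitive to substitution: pyridin-3-yl in place of methoxymethyl gives an at least 2.0-fold lower number from compound 2 to compound 3 (0.31 log units; beyond the scatter), and pyridin-3-yl in place of methyl gives an at least 2.0-fold lower number from compound 1 to compound 3 (0.31 log units; beyond the scatter). Both sizes are minimum values, as compound 1 and compound 2 each carry only a limit: the limit of > 3.33 h in this assay, at which 2 of the 3 values shown sit. The step from compound 1 to compound 2 cannot be read.

As far as these compounds go, whether the lower number goes with the six-membered aromatic ring as such or with its ring nitrogen stays open. Phenyl at the same carbon would separate the two.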